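This account rests on a few compounds, and the source may have more. Where it says the series, first, only, none or still open, it means among the compounds named here.

In a functional assay on MKN-45 cells (Homo sapiens) for inhibition, with a stated time of 72 h (on this read-out higher numbers stand for weaker inhibition and lower numbers for stronger inhibition), the series reads
Compound 1 `COc1ccc(S(=O)(=O)N2CCc3cccc(-c4ccc(F)c(F)c4)c32)cc1` gives 55.5 nM
Compound 2 `COc1ccc(S(=O)(=O)N2CCc3cccc(-c4ccc(N(C)C)cc4)c32)cc1` gives 237 nM
Compound 3 `COc1ccc(S(=O)(=O)N2CCc3cccc(-c4ccc(F)cc4)c32)cc1` gives 79 nM

The number for compound 3 keeps company with one neighbour (a 1.4-fold higher number from compound 1 to compound 3 (0.15 log units; within the scatter)) and stands apart from the other (a 3.0-fold lower number from compound 2 to compound 3 (0.48 log units; beyond the scatter)). Compound 4 `COc1ccc(S(=O)(=O)N2CCc3cccc(-c4ccncc4)c32)cc1` carries pyridin-4-yl in place of 4-fluorophenyl on an aromatic carbon. Among the compounds with values here, no measured step makes this exact exchange. The closest guide is the exchange of the whole aryl group that leads to compound 2 (a 4.3-fold higher number from compound 1 to compound 2 (0.63 log units; beyond the scatter)), a modest move to a higher number. A similar modest step to a higher number is expected in this assay (a 2.2-fold higher number from compound 3 to compound 4 (0.33 log units; beyond the scatter)). For compound 4 the estimated value is 170 nM, with an expected range from 60 nM to 480 nM.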

Compound 4, half-maximal inhibitory concentration: 69.5 nM
The estimate for compound 4 lay 2.4-fold (0.39 log units) above the measured number; the range from low to high includes it.
By their numbers in this assay, from the lowest: compounds 1, 4 and 3 (each within the scatter of the next); then compound 2.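

At this place, on an aromatic carbon ortho to a fused ring, pyridin-4-yl and 4-fluorophenyl read alike (a 1.1-fold lower number from compound 3 to compound 4 (0.06 log units; within the scatter)), so a ring with a hetero atom and a hydrogen-bond acceptor serves as well as a carbon-only ring. Pyridin-4-yl and 3,4-difluorophenyl also read alike (a 1.3-fold higher number from compound 1 to compound 4 (0.10 log units; within the scatter)), leaving 4-(dimethylamino)phenyl as the only aryl group of the four apart from the rest (a 3.4-fold lower number from compound 2 to compound 4 (0.53 log units; beyond the scatter)). No measurement at hand explains this. As far as these compounds go, whether a carboxylic acid or a primary amide on the aryl ring would stay in this range remains open.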